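The source may hold more compounds than are shown below. What is called first, only, known or untested is meant among the compounds shown, and "the series" means these compounds.

Measured so far:

Compound 1 `FC(F)(F)Oc1ccccc1Oc1ccnc(N2CCC(NC(=S)Nc3cccnc3)CC2)c1Cl`, 96 nM.

Compound 2 `FC(F)(F)c1cccnc1N1CCC(NC(=S)Nc2cccnc2)CC1`, > 5000 nM.

For the measured compounds named here, in an assay on membranes from brain for binding affinity to Lysophosphatidylserine lipase ABHD12 (Mus musculus), read by fluorescence, with a stated time of 20 min (on this read-out lower numbers stand for stronger inhibition and higher numbers for weaker inhibition), compound 1 gives 96 nM, the only number among the values shown. In this assay compound 2 reaches only > 5000 nM, which is a limit of the assay and not a number; the record shows (the limit of > 5000 nM in this assay, at which 1 of the 2 values shown sits). Compound 3 `FC(F)(F)Oc1ccc(Oc2ccnc(N3CCC(NC(=S)Nc4cccnc4)CC3)c2Cl)cc1` has not yet been measured. It differs from compound 1 in one place, 4-(trifluoromethoxy)phenyl in place of 2-(trifluoromethoxy)phenyl on an oxygen on an aromatic ring. Going by the values given here, no step between two measured compounds separates these two positions, so the size of the change cannot be read from the data. The step from compound 1 to compound 3 in this assay is expected to be a moderate loss, a 3.1-fold higher number from compound 1 to compound 3 (0.49 log units; beyond the scatter), which may or may not exceed the scatter. Compound 3 is therefore estimated at 300 nM, with a likely range from 60 nM to 2000 nM.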

Compound 3, half-maximal inhibitory concentration: 25 nM
Compound 3: the middle estimate sits 12-fold (1.08 log units) above what was measured, outside the stated range (below it).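

In this assay, placing 4-(trifluoromethoxy)phenyl in place of 2-(trifluoromethoxy)phenyl on an oxygen on an aromatic ring gives a 3.8-fold lower number from compound 1 to compound 3 (0.58 log units; beyond the scatter). For the compounds shown here, this is the first single-place comparison. The two compounds have the same atoms joined differently, and the comparison shows that the arrangement of the trifluoromethoxy group alone changes the read-out, with the 4-(trifluoromethoxy)phenyl compound giving the stronger inhibition of this pair. Nothing measured here accounts for this difference.

The compounds shown do not tell whether the trifluoromethoxy group itself is needed, since this comparison covers only its arrangement. From the compounds shown here alone, how a plain phenyl, or a phenyl carrying a methoxy group or a nitrile instead, would read in this assay remains open.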